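From 2-chlorobenzyl to 4-fluorobenzyl: working notes on the series

The source may hold more compounds than are shown below. What is called first, only, known or untested is meant among the compounds shown, and "the series" means these compounds.

Measured in a functional assay on PC-3 cells (Homo sapiens) for cytotoxicity, read by MTT assay, with a stated time of 24 h (a higher number here means a weaker inhibitor, a lower number a stronger inhibitor), so far:
- compound 1 `O=C1/C(=C/c2ccccc2F)CN(Cc2cn(Cc3ccccc3F)nn2)C/C1=C\c1ccccc1F` at 19700 nM
- compound 2 `O=C1/C(=C/c2ccccc2F)CN(Cc2cn(Cc3cccc(Cl)c3)nn2)C/C1=C\c1ccccc1F` at 6800 nM
- compound 3 `O=C1/C(=C/c2ccccc2F)CN(Cc2cn(Cc3ccccc3Cl)nn2)C/C1=C\c1ccccc1F` at 7100 nM

Compound 3 stands level with compound 2, with a 1.0-fold higher number from compound 2 to compound 3 (0.02 log units; within the scatter) inside the scatter. Compound 1 holds the highest number, and both a 2.8-fold lower number from compound 1 to compound 3 (0.44 log units; beyond the scatter) and a 2.9-fold lower number from compound 1 to compound 2 (0.46 log units; beyond the scatter) are modest steps beyond the scatter.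

The change from compound 3 to compound 4 `O=C1/C(=C/c2ccccc2F)CN(Cc2cn(Cc3ccc(F)cc3)nn2)C/C1=C\c1ccccc1F` is 4-fluorophenyl in place of 2-chlorophenyl on a saturated chain carbon bound to an aromatic nitrogen on the same chain carbon, so 2-chlorobenzyl gives way to 4-fluorobenzyl. Going by the values given here, no measured compound carries 4-fluorophenyl. Among the compounds with values here, the nearest guide is the single chloro and fluoro pair, a 2.8-fold lower number from compound 1 to compound 3 (0.44 log units; beyond the scatter) in that direction, which suggests a move back toward a higher number when fluoro replaces chloro. The change of chlorophenyl group in a 1.0-fold higher number from compound 2 to compound 3 (0.02 log units; within the scatter) offers no further signal.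

The expected move in this assay is a 1.8-fold higher number from compound 3 to compound 4 (0.26 log units; within the scatter) as a small rise at most, possibly not clearing the scatter. Compound 4 is estimated at 13000 nM with an expected range from 5500 nM to 27000 nM at this stage.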

Compound 4, half-maximal inhibitory concentration: 19400 nM
Compound 4: middle estimate off by 1.5-fold (0.17 log units), on the low side; measured number inside the range.
By their numbers in this assay, from the lowest: compounds 2 and 3 (each within the scatter of the next); then compounds 4 and 1 (each within the scatter of the next).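

In this assay, the return to a fluorobenzyl group undoes the gain seen with chloro: a 2.7-fold higher number from compound 3 to compound 4 (0.44 log units; beyond the scatter) and a 2.9-fold higher number from compound 2 to compound 4 (0.46 log units; beyond the scatter) are both modest steps beyond the scatter. Fluoro on the benzyl group, wherever it is named, gives no separation, since a 1.0-fold lower number from compound 1 to compound 4 (0.01 log units; within the scatter) leaves 2-fluorophenyl and 4-fluorophenyl level. Across these four compounds, the two chlorophenyl compounds 2 and 3 sit together and apart from the two fluorophenyl compounds 1 and 4, with no compound shown going against this grouping.

No measurement on hand bears on why the halogen separates these compounds. Still open, going by these compounds, is how 4-chlorophenyl, unsubstituted phenyl or a phenyl carrying an amine or a carboxylic acid would read on a saturated chain carbon bound to an aromatic nitrogen.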